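A few compounds are considered here, and "the series" means these few. Any claim that something is new, unique, unknown or untested is made for them only; others in the source may bear on it.

Measured in a functional assay on HeLa cells (Homo sapiens) for inhibition, read by MTT assay, with a stated time of 72 h; a higher number here means a weaker inhibitor, a lower number a stronger inhibitor:
- Compound 1 `COc1cc(NC(C)CCCNC(=O)NNC(=O)Nc2ccc(F)cc2)c2ncccc2c1`: >= 250000 nM (a limit, not a number)
- Compound 2 `COc1cc(NC(C)CCCNC(=O)Nc2ccc(F)cc2)c2ncccc2c1`: 20000 nM

Within the data shown here, compound 2, at 20000 nM, holds the only numeric value so far. The one other result, that of compound 1, is a limit. Compound 3 `COc1cc(NC(C)CCCNC(=O)Nc2cccc(O)c2)c2ncccc2c1` differs from compound 2 as follows: 3-hydroxyphenyl in place of 4-fluorophenyl on an amide-type nitrogen. That is, 3-hydroxyphenyl stands in place of 4-fluorophenyl on an amide-type nitrogen. Among the measured compounds shown here, the sole measured step, an at least 12-fold lower number from compound 1 to compound 2 (1.09 log units; beyond the scatter), is large and also falls on that nitrogen, but it keeps the 4-fluorophenyl and removes a longer piece. It shows that this end of the molecule can matter in this assay, yet it gives no size or direction for an exchange of one aryl group for another. For the measured compounds named here, no measured step covers such an exchange, so no shift beyond the scatter is expected, and the direction stays open. The estimated step is no change at the digits printed from compound 2 to compound 3 (within the scatter). For compound 3 the expected value is 20000 nM, with an expected range of 6000 nM to 70000 nM.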

Compound 3, half-maximal inhibitory concentration: 48000 nM
Compound 3: the middle estimate sits 2.4-fold (0.38 log units) below what was measured, within the range that was stated.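

In this assay, the aryl group on the amide-type nitrogen is not a neutral exchange: 3-hydroxyphenyl in place of 4-fluorophenyl gives a 2.4-fold higher number from compound 2 to compound 3 (0.38 log units; beyond the scatter), so a same-sized aryl swap moves the number, though only modestly and towards a weaker inhibitor. Against the ((4-fluorophenyl)carbamoyl)amino group, 3-hydroxyphenyl on that nitrogen gives an at least 5.2-fold lower number from compound 1 to compound 3 (0.71 log units; beyond the scatter), so the direction seen on removing the longer piece also holds with this second aryl group. That step is only a bound because compound 1 stands at a limit, not a number: the limit of >= 250000 nM in this assay, at which 1 of the 3 values shown sits.

The shift from compound 2 to compound 3 changes the substituent and its ring position together, so 4-hydroxyphenyl, 3-fluorophenyl or plain phenyl would be needed to separate the two. As far as these compounds go, whether an amine or a carboxylic acid on this ring would move the number, and in which direction, stays open.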